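The compounds below may be only part of what the source reports. "The series", "measured", "known", "first", "only" and "open" are said of these compounds alone.

Working notes on the series, read in a functional assay on HeLa cells (Homo sapiens) for antiproliferative activity, read by sulforhodamine B assay, with a stated time of 48 h; on this read-out lower numbers stand for stronger inhibition of growth and higher numbers for weaker inhibition of growth. Compound 1 (`CCCCCCCCCCCCCCC[C@@H](O)[C@@H](N)[C@@H](C)O`) gives 19000 nM, and compound 2 (`CCCCCCCCCCCCCCC[C@@H](O)[C@@H](N)C(C)C`) gives 21000 nM. Compound 3 (`CCCCCCCCC[C@@H](O)[C@@H](N)[C@@H](C)CC`) gives 20000 nM, which lies within the scatter of both other values, so it holds no distinct place among them.

Compound 4 (`CCCCCCCCCCCCCCC[C@@H](O)[C@@H](N)[C@@H](C)CC`) differs from compound 3 in one place: hexyl in place of hydrogen on a saturated chain carbon, ten or more bonds along the chain from an oxygen on a saturated carbon. This gives compound 4 the same long chain that compound 1 and compound 2 already carry.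

For the measured compounds named here, the only measured step is a 1.1-fold higher number from compound 1 to compound 2 (0.04 log units; within the scatter). It concerns a different part of the molecule and does not test the chain directly. The closest evidence on the chain comes from two values. Compound 3, with the shorter chain, stands at 20000 nM, and compound 2, with the longer chain, stands at 21000 nM. These lie within the scatter of each other, although the two compounds also differ in a second group. Going by the values given here, no measured pair isolates the hexyl change, so the expectation remains loose, and no shift beyond the scatter is expected.

The estimated outcome is a 1.1-fold lower number from compound 3 to compound 4 (0.05 log units; within the scatter). For compound 4 the expected value is 18000 nM, with an estimated range of 8000 nM to 35000 nM.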

Compound 4, concentration for 50% growth inhibition: 20000 nM
Compound 4: middle estimate off by 1.1-fold (0.05 log units), on the low side; the measured number falls inside the stated range.
By their numbers in this assay, from the lowest: compounds 1, 3, 4 and 2 (each within the scatter of the next).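

In this assay, hexyl in place of hydrogen on a saturated chain carbon, ten or more bonds along the chain from an oxygen on a saturated carbon, can now be read on its own, with no change at the digits printed from compound 3 to compound 4 (within the scatter); the earlier comparison of the two chain lengths carried a second difference, and this pair does not. Two more single-place pairs also stay within the scatter: methyl in place of hydrogen on a saturated chain carbon, three bonds along the chain from an amine nitrogen, gives a 1.1-fold lower number from compound 2 to compound 4 (0.02 log units; within the scatter), and ethyl in place of hydroxy on a saturated chain carbon bound to two saturated chain carbons gives a 1.1-fold higher number from compound 1 to compound 4 (0.02 log units; within the scatter). No supporting data on these compounds bear on what lies behind these readings.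

All the steps shown lie within the scatter, so none of these changes yet marks a place on the molecule where the read-out responds. Going by these compounds, whether a carboxylic acid or a phenyl ring in place of the hydroxy group, or a chain longer than that of compound 4, would give a step beyond the scatter remains open.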